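A few compounds are considered here, and "the series" means these few. Any claim that something is new, unique, unknown or untested is made for them only; others in the source may bear on it.

In a functional assay on HeLa cells (Homo sapiens) for antiproliferative activity, read by MTT assay, with a stated time of 72 h (on this read-out lower numbers stand for stronger inhibition and higher numbers for weaker inhibition), compound 1 (`O=C1COc2ccc(-c3cnc(Cl)c(NS(=O)(=O)c4ccc(F)cc4)c3)cc2N1c1ccc(F)cc1`) gives > 40000 nM, which is a limit of the assay and not a number. Among the compounds with values here, compound 2 (`O=C1COc2ccc(-c3cnc(Cl)c(NS(=O)(=O)c4ccc(F)cc4)c3)cc2N1`) gives 15600 nM, and the one measured step is an at least 2.5-fold lower number from compound 1 to compound 2 (0.40 log units; beyond the scatter). Compound 3 (`COc1cccc(N2C(=O)COc3ccc(-c4cccc(NS(=O)(=O)c5ccc(F)cc5)c4)cc32)c1`) gives > 40000 nM, again only a limit, so it stands at the limit of > 40000 nM in this assay, at which 2 of the 3 values shown sit. Compound 4 (`COc1ccc(N2C(=O)COc3ccc(-c4cccc(NS(=O)(=O)c5ccc(F)cc5)c4)cc32)cc1`) differs from it as follows: 4-methoxyphenyl in place of 3-methoxyphenyl on an amide-type nitrogen in a ring. The measured step bears on this place only loosely, since it removes the group from the core of compound 1, whereas here the group stays and only its methoxy changes place. The expected size is therefore none beyond the scatter: a number no higher from compound 3 to compound 4 (the limit leaves the size open). For compound 4 the estimate is 40000 nM, with an expected range from 18000 nM to 80000 nM.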

Compound 4, half-maximal inhibitory concentration: 13200 nM
Compound 4: middle estimate off by 3.0-fold (0.48 log units), on the high side; measured number below the stated range.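

The step, an at least 3.0-fold lower number from compound 3 to compound 4 (0.48 log units; beyond the scatter), shows that in this assay this nitrogen position responds to where the methoxy stands on the phenyl group, even with the same atoms. The earlier step showed only the loss of a whole group from this nitrogen. Compound 3 stands only at a limit of the assay: the limit of > 40000 nM in this assay, at which 2 of the 4 values shown sit.

The compounds shown leave open whether an ethoxy group, a hydroxyl or an amine in place of the methoxy of the 4-methoxyphenyl group would lower the number further. They also leave open whether the same change holds on the core of compound 1.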